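Amine-aryl exchange on the shared core: compound 4

A few compounds are considered here, and "the series" means these few. Any claim that something is new, unique, unknown or untested is made for them only; others in the source may bear on it.

Compound 1 `O=C(/C=C\Nc1ccc(F)cc1)c1nc(-c2ccc(F)cc2)n2ccccc12` is tested in a functional assay on B16-F10 cells (Mus musculus) for cytotoxicity, read by MTT assay, with a stated time of 48 h; a higher number here means a weaker inhibitor, a lower number a stronger inhibitor. In this assay compound 1 gives only a limit, > 30000 nM. Compound 3 `O=C(/C=C\Nc1ccc(F)cc1)c1nc(-c2ccc(C(F)(F)F)cc2)n2ccccc12` also reaches only a limit in this assay, > 30000 nM. The step that the two limits leave unreadable from compound 1 to compound 3 is thus unreadable, and it sits on the aryl group of the core rather than on the amine nitrogen. Differing from compound 1 in two places, compound 2 `COc1ccc(-c2nc(C(=O)/C=C\Nc3ccc4[nH]ccc4c3)c3ccccn23)cc1` gives 5120 nM in this assay, the one numerical value against (the limit of > 30000 nM in this assay, at which 2 of the 3 values shown sit). Compound 4 `COc1ccc(N/C=C\C(=O)c2nc(-c3ccc(F)cc3)n3ccccc23)cc1OC` carries 3,4-dimethoxyphenyl in place of 4-fluorophenyl on an amine nitrogen. Going by the values given here, no measured step bears on this change at the amine nitrogen. Compound 4 is expected to give 20000 nM, in the range 5000 nM to 60000 nM, with a real chance of a limit instead. The expected step is an at least 1.5-fold lower number from compound 1 to compound 4 (0.17 log units; that floor lies within the scatter), uncertain in direction.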

Compound 4, half-maximal inhibitory concentration: > 30000 nM
Compound 4: a limit, no number; the forecaster's own chance of this, stated with the estimate: 55%; at least 1.5-fold (0.17 log units) between middle value and limit.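

Going by these compounds alone, compound 4 gives only a limit in this assay, > 30000 nM; compound 1 is also a limit, so no step between them can be read. The compounds shown leave open how the aryl group on the amine nitrogen alone affects cytotoxicity.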